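A few compounds are considered here, and "the series" means these few. Any claim that something is new, unique, unknown or untested is made for them only; others in the source may bear on it.

Three members of one series have been tested in a functional assay on the whole organism (artery, strain albino) with Rattus norvegicus as the target, with a stated time of 180 min, at a dose of 10 mg/kg by the oral route; a lower number here means less inhibition, a higher number more inhibition at the dose given (going by the name of the read-out). Compound 1, `COc1ccc(C2N=C(SCc3ccc(Cl)cc3)NC(C)=C2C(=O)Nc2ccc(F)cc2)cc1OC`, gives 20.1% in that setting. Compound 2, `COc1ccc(C2N=C(SCc3ccc(F)cc3)NC(C)=C2C(=O)Nc2ccc(F)cc2)cc1OC`, gives 22.2%. Compound 3, `CC1=C(C(=O)Nc2ccc(F)cc2)C(c2ccc([N+](=O)[O-])cc2)N=C(SCc2ccc(Cl)cc2)N1`, gives 23.2%. The three numbers sit close together, and none of the differences among them is larger than the scatter of the measurement.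

Compound 2 is obtained from compound 1 by fluoro in place of chloro on an aromatic carbon, and this produced a number 2.1 percentage points higher from compound 1 to compound 2 (within the scatter). Compound 3 is obtained from compound 1 by 4-nitrophenyl in place of 3,4-dimethoxyphenyl on a saturated ring carbon, and this produced a number 3.1 percentage points higher from compound 1 to compound 3 (within the scatter).

Compound 4, `CC1=C(C(=O)Nc2ccc(F)cc2)C(c2ccc([N+](=O)[O-])cc2)N=C(SCc2ccc(F)cc2)N1`, has not yet been measured. It differs from compound 3 by fluoro in place of chloro on an aromatic carbon, the same change that turns compound 1 into compound 2, now made on the core of compound 3 rather than on the core of compound 1; the two cores differ by 4-nitrophenyl in place of 3,4-dimethoxyphenyl on a saturated ring carbon.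

Within the data shown here, the expected step from compound 3 to compound 4 in this assay is a number 1.8 percentage points higher from compound 3 to compound 4 (within the scatter), resting on the single precedent a number 2.1 percentage points higher from compound 1 to compound 2 (within the scatter). On that basis compound 4 is expected to give about 25%, with a likely range from 15% to 35%.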

Compound 4, a percentage reported as inhibition, in the whole organism at one dose (the size of the read-out at that dose, not a potency): 20.1%
Compound 4: middle estimate off by 4.9 percentage points, on the high side; the measured number falls inside the stated range.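

In this assay, fluoro in place of chloro, now on the core bearing 4-nitrophenyl, gave a number 3.1 percentage points lower from compound 3 to compound 4 (within the scatter), and 4-nitrophenyl in place of 3,4-dimethoxyphenyl, now with fluoro present, gave a number 2.1 percentage points lower from compound 2 to compound 4 (within the scatter). The fluoro-for-chloro change therefore shows no difference between the two cores that can be told from scatter, but steps this small do not show that it carries over as a real effect, nor that it has any effect on either core: the same change on two cores in this assay, a number 2.1 percentage points higher (within the scatter) from compound 1 to compound 2 and a number 3.1 percentage points lower (within the scatter) from compound 3 to compound 4, 5.2 percentage points apart, within the scatter of two such steps. The exchange of the aromatic groups reads the same way, with no dependence on the other position shown and no effect of its own established: the same change on two cores in this assay, a number 3.1 percentage points higher (within the scatter) from compound 1 to compound 3 and a number 2.1 percentage points lower (within the scatter) from compound 2 to compound 4, 5.2 percentage points apart, within the scatter of two such steps.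

The compounds shown cover only chloro and fluoro on the benzyl group, so it remains open how a methoxy group, an amine or a carboxylic acid would behave at that place. They also leave open whether a longer chain in place of the benzyl group would give steps large enough to be read beyond the scatter.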